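Selenium substituent swap: notes on compounds 1 to 4

The compounds below may be only part of what the source reports. "The series", "measured", "known", "first", "only" and "open" are said of these compounds alone.

Measured so far in a functional assay on MDA-MB-231 cells (Homo sapiens) for inhibition, read by MTT assay, with a stated time of 48 h; a lower number here means a stronger inhibitor, a higher number a weaker inhibitor:
compound 1, `COc1ccc(N(C)c2nc(C)nc3ccccc23)cc1[Se]C`, gives 10 nM
compound 2, `Cc1nc(N(C)c2ccc([Se]C#N)c(Cl)c2)c2ccccc2n1`, gives 9 nM
compound 3, `COc1ccc(N(C)c2nc(C)nc3ccccc23)cc1[Se]C#N`, gives 52 nM

Compounds 1 and 3 share one core and differ only at the selenium: methyl in place of cyano on a selenium. That change gives a 5.2-fold lower number from compound 3 to compound 1 (0.72 log units; beyond the scatter), a step that lies beyond the scatter. Compound 2 carries a different core; the difference between the two cores is not broken down here. In this assay compound 2 and compound 1 lie within the scatter of each other, so no order is drawn between them.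

Compound 4, `C[Se]c1ccc(N(C)c2nc(C)nc3ccccc23)cc1Cl`, is not yet measured. It differs from compound 2 by methyl in place of cyano on a selenium, the same change as from compound 3 to compound 1, made at the same kind of place. On that single precedent, a step of similar size is expected, namely a 3.6-fold lower number from compound 2 to compound 4 (0.56 log units; beyond the scatter). For the measured compounds named here, because compound 2 already gives 9 nM, the expected number for compound 4 is low, and with only one prior step the range is kept wide. Compound 4 is estimated at 2.5 nM, between 1 nM and 8 nM.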

Compound 4, half-maximal inhibitory concentration: 7 nM
The estimate for compound 4 lay 2.8-fold (0.45 log units) below the measured number; the range from low to high includes it.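

In this assay methyl in place of cyano on a selenium gives a 1.3-fold lower number from compound 2 to compound 4 (0.11 log units; within the scatter) and this step stays within the scatter, so no effect of the change can be claimed on that core. The change therefore does not carry over in size from one core to the other: (the same change on two cores in this assay, a 5.2-fold lower number (0.72 log units; beyond the scatter) from compound 3 to compound 1 and a 1.3-fold lower number (0.11 log units; within the scatter) from compound 2 to compound 4, 4.0-fold (0.61 log units) apart, beyond the scatter of two such steps). These two pairs show that the size of the step cannot be assumed to transfer between these two cores, but they do not show which difference between the cores accounts for the gap, nor which of the two steps would be the more typical on a further core.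

The selenium carries only methyl or cyano in the compounds shown, so the outcome with a longer chain such as ethyl or propyl, or with a phenyl group, remains open. Also open, on these data alone, is whether the same swap on a third core would follow the larger step or the smaller one.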